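Swapping a benzyloxy for bromo on an uncharged biaryl amide

The source may hold more compounds than are shown below. What is called first, only, known or untested is meant among the compounds shown, and "the series" means these compounds.

Measured compounds and their values:
Compound 1, `CCOC(=O)CCCCCOc1cccc(CN(C(=O)c2ccc(-c3cccc(NC(C)=O)c3)cc2)C(C)C)c1`: > 26000 nM
Compound 2, `CCOC(=O)CCCCCOc1cccc(CN(C(=O)c2ccc(-c3cccc(C(C)=O)c3)cc2)C(C)C)c1`: > 26000 nM
Compound 3, `CCOC(=O)CCCCCOc1cccc(CN(C(=O)c2ccc(-c3cccc(OCc4ccccc4)c3)cc2)C(C)C)c1`: > 26000 nM

The three compounds share one core and differ only in the group on the outer aromatic ring. In an ADME assay on HepG2 cells (Homo sapiens) for cytotoxicity, read by CellTiter-Glo and resazurin assay, with a stated time of 72 h (a lower number here means that less compound is needed, a higher number that more compound is needed for the effect), compound 1 gives > 26000 nM, which is a limit of the assay rather than a number. In the same assay compound 2 gives > 26000 nM, again a limit. Compound 3 gives > 26000 nM, also a limit. Where compound 3 stands among these values cannot be told, since the limit of > 26000 nM in this assay, at which 3 of the 3 values shown sit: all three sit at the same limit, and the three steps a step that the two limits leave unreadable from compound 1 to compound 2, a step that the two limits leave unreadable from compound 1 to compound 3 and a step that the two limits leave unreadable from compound 2 to compound 3 therefore stay unreadable.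

Compound 4, `CCOC(=O)CCCCCOc1cccc(CN(C(=O)c2ccc(-c3cccc(Br)c3)cc2)C(C)C)c1`, has not been measured. It differs from compound 3 in this way: bromo in place of benzyloxy on an aromatic carbon. Among the compounds with values here, because of the limit of > 26000 nM in this assay, at which 3 of the 3 values shown sit, no measured step can give a size or direction for this change. For compound 4 the step that the limit leaves unreadable from compound 3 to compound 4 is therefore estimated as none beyond the scatter. In this assay compound 4 is expected to give about 30000 nM, with a range from 15000 nM to 80000 nM, most likely reported again as a limit.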

Compound 4, half-maximal effective concentration: > 26000 nM
Compound 4: only a limit was reported (the forecaster's own chance of this, stated with the estimate: 80%); the middle value lies beyond the limit too.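

In this assay, compound 4 sits at a limit, as do compound 1, compound 2 and compound 3, so no step from any of these to compound 4 can be read: the limit of > 26000 nM in this assay, at which 4 of the 4 values shown sit.

The compounds shown leave open how far apart these four lie, and whether any group on the outer aromatic ring gives a value that can be read as a number.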